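Adding a Fluorine to the Anilide Ring of Compound 1

The source may report more compounds than this note shows. Statements on the series, on what has been measured and on what is new or still open speak of the compounds shown alone.

Compound 1 `Cc1cc(=O)n(-c2ccc(F)cc2)nc1C(=O)Nc1ccc(Oc2ncnc3[nH]ccc23)cc1` was tested in a functional assay on A549 cells (Homo sapiens) for cytotoxicity, read by MTT assay, with a stated time of 72 h; on this read-out higher numbers stand for weaker inhibition and lower numbers for stronger inhibition. In this assay compound 1 gives > 60000 nM, which is a limit of the assay and not a measured number. Compound 2 `Cc1cc(=O)n(-c2ccc(Br)cc2F)nc1C(=O)Nc1ccc(Oc2ncnc3[nH]ccc23)cc1` gives 3770 nM in this assay. The step from compound 1 to compound 2 is an at least 15-fold lower number from compound 1 to compound 2 (1.20 log units; beyond the scatter), but it changes the ring on the aromatic nitrogen, not the anilide ring.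

Compound 3 `Cc1cc(=O)n(-c2ccc(F)cc2)nc1C(=O)Nc1ccc(Oc2ncnc3[nH]ccc23)c(F)c1` differs from compound 1 by fluoro in place of hydrogen on an aromatic carbon, on an aromatic carbon of a six-membered aromatic ring of carbon only. Among the measured compounds shown here, no measured step changes that position, so nothing directly shows its effect. Because the limit of > 60000 nM in this assay, at which 1 of the 2 values shown sits, is where compound 1 sits, only a large gain could be seen at all. The expected step from compound 1 to compound 3 is a number no higher from compound 1 to compound 3 (the limit leaves the size open), with the estimate for compound 3 at 60000 nM, between 20000 nM and 200000 nM.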

Compound 3, half-maximal inhibitory concentration: 42400 nM
Compound 3: middle estimate off by 1.4-fold (0.15 log units), on the high side; measured number inside the range.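

In this assay, fluoro in place of hydrogen on this aromatic carbon of the anilide ring gives an at least 1.4-fold lower number from compound 1 to compound 3 (0.15 log units; that floor lies within the scatter). Unlike the step to compound 2, which changes the ring on the aromatic nitrogen, this step is the first to show the anilide ring changing on its own, and compound 3 gives a measured number. Compound 1 has only a limit, so the true size of the step stays unknown and this floor alone does not establish a gain: the limit of > 60000 nM in this assay, at which 1 of the 3 values shown sits.

The compounds shown leave open whether another group on this carbon, such as chloro, methoxy or an amine, would move the number further. They also leave open whether fluoro here would give a readable step alongside the 4-bromo-2-fluorophenyl group of compound 2, where the starting value is a measured number.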